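Chloro or Trifluoromethyl: One Change on Two Cores

The source may hold more compounds than are shown below. What is called first, only, known or untested is meant among the compounds shown, and "the series" means these compounds.

Of the compounds shown here, three have been measured in a functional assay on CHO cells for antagonist activity at Orexin/Hypocretin receptor type 1 (Homo sapiens), read by FLIPR and calcium flux; a lower number here means a less potent compound, a higher number a more potent compound, by a factor of ten per unit of this negative logarithm. Compound 1 `Cc1nc(C(=O)N2CCC3(CC3)C[C@H]2CNc2ccc(C(F)(F)F)cn2)c(-c2ccccc2)s1` and compound 2 `Cc1nc(C(=O)N2CCC3(CC3)C[C@H]2CNc2ccc(Cl)cn2)c(-c2ccccc2)s1` share one core, and differ only by trifluoromethyl in place of chloro on an aromatic carbon. Compound 3 `Cc1ccc(-c2ncccn2)c(C(=O)N2CC3(CC3)C[C@H]2CNc2ccc(Cl)cn2)c1` sits on a second core, and how the two cores differ is not broken down here. Compound 4 `Cc1ccc(-c2ncccn2)c(C(=O)N2CC3(CC3)C[C@H]2CNc2ccc(C(F)(F)F)cn2)c1` is the partner of compound 3 on that second core, made by the same kind of change, (trifluoromethyl in place of chloro on an aromatic carbon), and it has not yet been measured.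

In this assay compound 2 gives 7.9, and compound 1 gives 7.7, so the change made a number 0.20 log units lower from compound 2 to compound 1 (within the scatter). Compound 3 gives 8.2 in this assay, the highest of the three numbers, though its gap to compound 2 is within the scatter.

For compound 4 the step is expected to be a number 0.20 log units lower from compound 3 to compound 4 (within the scatter), because the same change on the first core gave a number 0.20 log units lower from compound 2 to compound 1 (within the scatter). On that basis compound 4 is estimated to give 8 in this assay, with a likely span from 7.5 to 8.5.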

Compound 4, negative logarithm of the antagonist equilibrium constant: 8.7
Compound 4: the middle estimate sits 0.70 log units below what was measured, outside the stated range (above it).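

In this assay, putting trifluoromethyl in place of chloro gives a number 0.50 log units higher from compound 3 to compound 4 (beyond the scatter), and this step does not match the one seen on the first core: the same change on two cores in this assay, a number 0.20 log units lower (within the scatter) from compound 2 to compound 1 and a number 0.50 log units higher (beyond the scatter) from compound 3 to compound 4, 0.70 log units apart, beyond the scatter of two such steps

In this series, then, the effect of this change depends on the core that carries it, and a step read on one core cannot simply be carried over to the other. With a single pair on each core, these numbers do not show why the two steps part, which portion of the cores is responsible, or how the same change would behave on any third core.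

The compounds shown carry only chloro or trifluoromethyl at this place on the ring, so it remains open whether a nitrile, a methyl or a methoxy group there would also give steps that differ from core to core. Also open, from the compounds shown here alone, is how a core that mixes features of the two would respond to the same change.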